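Swapping a chlorine for a fluorine on the triazole aryl

The source may hold more compounds than are shown below. What is called first, only, known or untested is meant among the compounds shown, and "the series" means these compounds.

Measured so far in a functional assay on SW-620 cells (Homo sapiens) for antiproliferative activity, read by MTT assay, with a stated time of 72 h; on this read-out lower numbers stand for stronger inhibition and higher numbers for weaker inhibition:
compound 1, `CCCCCCC#Cc1c(CCCCCC)oc2nc(=O)n(Cc3cn(Cc4ccccc4)nn3)cc12`: 32600 nM
compound 2, `CCCCCCC#Cc1c(CCCCCC)oc2nc(=O)n(Cc3cn(-c4ccc(Cl)cc4)nn3)cc12`: > 100000 nM (a limit of the assay, not a number)
compound 3, `CCCCCc1ccc(C#Cc2c(-c3ccc(CCCCC)cc3)oc3nc(=O)n(Cc4cn(Cc5ccccc5)nn4)cc23)cc1`: > 100000 nM (a limit of the assay, not a number)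

Compound 1 is the only one of the three with a measured number in this assay. From the compounds shown here alone, compound 2 reaches only the limit of this assay, so its true value is unknown beyond that bound. The change that leads from compound 1 to compound 2 gives an at least 3.0-fold higher number from compound 1 to compound 2 (0.48 log units; beyond the scatter).

Compound 4, `CCCCCCC#Cc1c(CCCCCC)oc2nc(=O)n(Cc3cn(-c4ccc(F)cc4)nn3)cc12`, is not yet measured. It differs from compound 2 by fluoro in place of chloro on an aromatic carbon. Within the data shown here, no measured pair here changes a halogen on that ring, so there is no direct step to lean on. Because compound 2 reaches > 100000 nM and the change is small, compound 4 is expected to stay weak. Compound 4 is estimated at 100000 nM, within 30000 nM to 300000 nM. This estimate means a step of a number no higher from compound 2 to compound 4 (the limit leaves the size open), expected to be within the scatter.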

Compound 4, half-maximal inhibitory concentration: > 100000 nM
Compound 4: only a limit was reported; the forecaster's own chance of this, stated with the estimate: 60%; the middle value sits exactly at the limit.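

Putting fluoro in place of chloro at this spot on the aryl ring does not bring back a measurable value in this assay: compound 4, like compound 2, ends at a limit of the assay rather than a number, so the step between them cannot be read. The comparison with the benzyl compound now has a second member, with an at least 3.0-fold higher number from compound 1 to compound 4 (0.48 log units; beyond the scatter), so the loss seen with 4-chlorophenyl in place of benzyl also appears with 4-fluorophenyl and does not hang on one halogen. Any real difference between the two halogens stays hidden, as most of these compounds end at the same ceiling: the limit of > 100000 nM in this assay, at which 3 of the 4 values shown sit.

From the compounds shown here alone, it remains open whether a plain phenyl, or a phenyl carrying a methoxy group or an amine, would give a measurable number here. Also open, going by these compounds, is whether a benzyl carrying chloro or fluoro would keep the activity of compound 1.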